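Acid dissociation in a furanylmethyl diamine series

The source may hold more compounds than are shown below. What is called first, only, known or untested is meant among the compounds shown, and "the series" means these compounds.

Compound 3 `c1coc(CNCCCNc2ccnc3cc(-c4cccc5ccccc45)ccc23)c1` gives 9.47 in a physicochemical assay for acid dissociation. It stands level with compound 2 `c1coc(CNCCCNc2ccnc3cc(CC4CCCCC4)ccc23)c1`, which gives 9.47, the two together the highest of three numbers that all lie within the scatter of one another; compound 1 `COc1ccc(Oc2ccc3c(NCCCNCc4ccco4)ccnc3c2)cc1` gives 9.28, with a number 0.19 log units higher from compound 1 to compound 3 (within the scatter), a number 0.19 log units higher from compound 1 to compound 2 (within the scatter) and no change at the digits printed from compound 2 to compound 3 (within the scatter). Compound 4 `c1coc(CNCCCNc2ccnc3cc(C4CCCCC4)ccc23)c1` is not yet measured in this assay; it differs from compound 3 by cyclohexyl in place of naphthalen-1-yl on an aromatic carbon. Within the data shown here, the steps that bear on this change each swap one group on the same aromatic carbon and move nothing beyond the scatter, so for this assay no step beyond the scatter is expected. The expected step is a number 0.02 log units lower from compound 3 to compound 4 (within the scatter). Compound 4 is estimated at 9.45, with a range from 9.15 to 9.75.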

Compound 4, acid dissociation constant: 9.47
Beside the measured number, compound 4's estimate is 0.02 log units below it, within the range that was stated.
By their numbers in this assay, from the lowest: compounds 1, 2, 3 and 4 (each within the scatter of the next).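

In this assay, cyclohexyl in place of naphthalen-1-yl on the aromatic carbon gives no change at the digits printed from compound 3 to compound 4 (within the scatter); in place of cyclohexylmethyl it gives no change at the digits printed from compound 2 to compound 4 (within the scatter), and in place of 4-methoxyphenoxy it gives a number 0.19 log units higher from compound 1 to compound 4 (within the scatter). A single non-aromatic ring bonded directly to this carbon thus joins the two aromatic rings of naphthalen-1-yl, the cyclohexylmethyl group and 4-methoxyphenoxy within the scatter of one another. No independent evidence bears on this result.

Open, as far as these compounds go, is whether a group such as an amine or a carboxylic acid at this position would give a step beyond the scatter.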